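The source may hold more compounds than are shown below. What is called first, only, known or untested is meant among the compounds shown, and "the series" means these compounds.

In an ADME assay on Huh-7 cells (Homo sapiens) for cytotoxicity, with a stated time of 72 h (a higher number here means that more compound is tolerated, a lower number that less compound is tolerated), compound 1 `CC(C)CC(C)n1nc(-c2cccs2)c(O)c(C2=NS(=O)(=O)c3cc(NS(C)(=O)=O)ccc3N2)c1=O` gives > 33000 nM as a limit of the assay, not a number. For the measured compounds named here, compound 2 `CS(=O)(=O)Nc1ccc2c(c1)S(=O)(=O)N=C(c1c(O)c(-c3cccs3)nn(CCC3CCC3)c1=O)N2` gives > 1000 nM as a limit too, so it stands on no number, and the only other value beside it is also a limit. Compound 3 `CS(=O)(=O)Nc1ccc2c(c1)S(=O)(=O)N=C(c1c(O)c(-c3cccs3)nn(CCC3CCCCC3)c1=O)N2` differs from compound 2 by cyclohexyl in place of cyclobutyl on a saturated chain carbon, two bonds along the chain from an aromatic nitrogen and carries cyclohexyl in place of cyclobutyl on a saturated chain carbon, two bonds along the chain from an aromatic nitrogen. Going by the values given here, the one measured step bearing on this change, made in the same substituent, is a step that the two limits leave unreadable from compound 1 to compound 2 and it offers no size to carry over. An estimated step that the limit leaves unreadable from compound 2 to compound 3 is therefore expected, but only loosely, since it starts from a limit. Compound 3 is estimated at 15000 nM in this assay with 3000 nM to 50000 nM as the expected range, and another limit is quite possible.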

Compound 3, half-maximal cytotoxic concentration: > 17000 nM
Compound 3: only a limit was reported; the forecaster's own chance of this, stated with the estimate: 65%; middle value at least 1.1-fold (0.05 log units) from the limit.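

In this assay compound 3 gives > 17000 nM, a limit of the assay and not a number. For the compounds shown here, compound 1, compound 2 and compound 3 all stand on limits, so no step between them can be read. Where the actual tolerated concentration of each lies remains open.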